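From compound 2 to compound 4: a 4-bromophenyl swap

The compounds below may be only part of what the source reports. "The series", "measured", "known", "first", "only" and "open" are said of these compounds alone.

In a functional assay on the whole organism (strain Kunming) with Mus musculus as the target, with a stated time of 0.5 h (on this read-out higher numbers stand for an effect only at larger amounts of compound and lower numbers for an effect already at smaller amounts), compound 2 (`COc1cc(OC)c(OC)cc1/C=C/COC(=O)/C=C/c1ccc(OC)c(OC)c1`) gives (58.1 mg/kg) and stands within the scatter of both neighbours: compound 1 (`COc1ccccc1/C=C/C(=O)OC/C=C/c1cc(OC)c(OC)cc1OC`) at (39 mg/kg) and compound 3 (`COc1cc(OC)c(OC)cc1/C=C/COC(=O)/C=C/c1c(OC)ccc(OC)c1OC`) at (53.5 mg/kg). The three values show no separation.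

Compound 4 (`COc1cc(OC)c(OC)cc1/C=C/COC(=O)/C=C/c1ccc(Br)cc1`) carries 4-bromophenyl in place of 3,4-dimethoxyphenyl on a double-bonded chain carbon bound to a double-bonded chain carbon. For the measured compounds named here, the one measured step at this place (a 1.5-fold higher number from compound 1 to compound 2 (0.17 log units; within the scatter)) stays within the scatter and is the closest guide available. Going by the values given here, no measured compound carries bromine, so that guide reaches the new group only loosely, and the range has to stay wide.

The expected step is (a 1.2-fold lower number from compound 2 to compound 4 (0.07 log units; within the scatter)) with no shift beyond the scatter and no direction favoured. For compound 4 the estimated value in this assay is (50 mg/kg) with an expected range from (24 mg/kg) to (105 mg/kg).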

Compound 4, dose for half-maximal effect: 61.8 mg/kg
Estimate against measurement, compound 4: 1.2-fold (0.09 log units) below; measured number inside the range.
By their numbers in this assay, from the lowest: compounds 1, 3, 2 and 4 (each within the scatter of the next).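

In this assay, 4-bromophenyl in place of 3,4-dimethoxyphenyl on a double-bonded chain carbon bound to a double-bonded chain carbon gives (a 1.1-fold higher number from compound 2 to compound 4 (0.03 log units; within the scatter)), and 4-bromophenyl in place of 2-methoxyphenyl at the same place gives (a 1.6-fold higher number from compound 1 to compound 4 (0.20 log units; within the scatter)). The earlier compounds shown here varied only the methoxy groups on this ring, whereas compound 4 shows that a ring with bromine and no methoxy group, with none of the hydrogen-bond acceptors counted for 3,4-dimethoxyphenyl, also stays within the scatter. No supporting data are at hand to explain why this place responds so little.

All groups shown at this place are substituted phenyl rings, so no step here yet reaches beyond the scatter. As far as these compounds go, whether an amine, a carboxylic acid or a longer chain on this ring would move the number beyond the scatter remains open.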